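A few compounds are considered here, and "the series" means these few. Any claim that something is new, unique, unknown or untested is made for them only; others in the source may bear on it.

Measured so far:
- Compound 1 `COc1ccc(C(=O)Nc2ccccc2)cc1NC(=O)c1ccccc1`: 193 uM
- Compound 2 `COc1ccc(C(=O)Nc2ccccc2)cc1NC(=O)C1CCCC1`: 459 uM

In an ADME assay on MDCK cells (Canis lupus familiaris) for cytotoxicity, read by cytopathic effect, with a stated time of 48 h (a higher number here means that more compound is tolerated, a lower number that less compound is tolerated), compound 2 holds the higher of the two numbers, and compound 1 gives 193 uM. Among the measured compounds shown here, the only measured step, a 2.4-fold higher number from compound 1 to compound 2 (0.38 log units; beyond the scatter), concerns the same position that changes next, and it is modest.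

Compound 3 `CCC(=O)Oc1cc(C(=O)Nc2ccccc2)ccc1OC` is the next member. It differs from compound 2 by propanoyloxy in place of (cyclopentylcarbonyl)amino on an aromatic carbon. This change touches the place that the measured step altered, but it goes further: the whole (cyclopentylcarbonyl)amino group leaves, and a propanoyloxy group enters. For the measured compounds named here, no measured pair tracks a move from an amide to an ester here, so the step from compound 1 to compound 2 bears on it only loosely, as a sign that this position can shift the number in this assay beyond the scatter.

Given this, compound 3 is expected to land in the region spanned by the two measured compounds, with a step of a 1.6-fold lower number from compound 2 to compound 3 (0.21 log units; within the scatter), most likely a small decrease rather than a gain. The estimate for compound 3 is 280 uM, within 120 uM to 650 uM.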

Compound 3, half-maximal toxic concentration: 519 uM
Compound 3: the middle estimate sits 1.9-fold (0.27 log units) below what was measured; the measured number falls inside the stated range.
By their numbers in this assay, from the lowest: compound 1; then compounds 2 and 3 (each within the scatter of the next).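

In this assay, propanoyloxy in place of (cyclopentylcarbonyl)amino on an aromatic carbon, ortho to a methoxy group, gives a 1.1-fold higher number from compound 2 to compound 3 (0.05 log units; within the scatter), so the two compounds stand within the scatter of each other. The exchange removes the five-membered ring and the hydrogen-bond donor of the leaving group and swaps the amide link for an ester, yet the number stays level with that of compound 2, whereas the earlier change at this position, a 2.4-fold higher number from compound 1 to compound 2 (0.38 log units; beyond the scatter), went beyond the scatter; this position therefore tolerates a far larger structural change than that earlier step showed, with no loss beyond the scatter, and the lowest number remains that of compound 1, at 193 uM. Nothing available here accounts for this agreement between the two numbers.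

Compound 2 and compound 3 differ in both the link and the acyl part, so the shown compounds cannot separate the contribution of each, and a propanoyl amide or a cyclopentanecarboxylate ester would be needed to pull them apart. Going by these compounds, how a free amine, a carboxylic acid or a longer acyl chain at this position would read in this assay also remains open.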